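The compounds below may be only part of what the source reports. "The series", "measured", "known", "first", "only" and "open" are said of these compounds alone.

Compound 1 `Cc1c(C)n(Cc2ccccc2)c2ncn(C3CCOCC3)c(=N)c12`: 1680 10^-6 cm/s
Compound 2 `COc1ccc(-c2c(-c3ccc(OC)cc3)n(Cc3ccccc3)c3ncn(CCCO)c(=N)c23)cc1`: > 1000 10^-6 cm/s
Compound 3 `COc1ccc(Cn2c(-c3ccccc3)c(-c3ccccc3)c3c(=N)n([C@H]4CC[C@H](O)CC4)cnc32)cc1`: > 1000 10^-6 cm/s

In an ADME assay for permeability, using PAMPA, with a stated time of 30 min, at pH 7.4 (a lower number here means that the compound crosses the layer more slowly, a higher number that the compound crosses the layer faster), compound 1 gives 1680 10^-6 cm/s. For compound 2 the reading is a limit of the assay, > 1000 10^-6 cm/s. For compound 3 the reading is likewise a limit of the assay, > 1000 10^-6 cm/s. Compound 3 therefore sits at the limit of > 1000 10^-6 cm/s in this assay, at which 2 of the 3 values shown sit, so its place among the three cannot be ranked further.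

Compound 4 `COc1ccc(Cn2c(-c3ccccc3)c(-c3ccccc3)c3c(=N)n(CCO)cnc32)cc1` differs from compound 3 by 2-hydroxyethyl in place of 4-hydroxycyclohexyl on an aromatic nitrogen, in words 2-hydroxyethyl in place of 4-hydroxycyclohexyl on an aromatic nitrogen. Going by the values given here, no two measured compounds differ in only one place, so no measured step guides this change. The step from compound 3 to compound 4 in this assay is expected to be a step that the limit leaves unreadable from compound 3 to compound 4, nothing beyond the scatter. Compound 4 is expected to give 1200 10^-6 cm/s, between 600 10^-6 cm/s and 2500 10^-6 cm/s, most likely reported again as a limit.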

Compound 4, apparent permeability: > 1000 10^-6 cm/s
Compound 4: only a limit was reported; the forecaster's own chance of this, stated with the estimate: 70%; the middle value lies beyond the limit too.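

Going by these compounds alone, compound 3 and compound 4 are both reported only as limits, and no step between them can be read. In this assay the compounds shown leave open how far 2-hydroxyethyl and 4-hydroxycyclohexyl on an aromatic nitrogen really differ.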